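This account rests on a few compounds, and the source may have more. Where it says the series, first, only, none or still open, it means among the compounds named here.

Going by the values given here, compound 2 `CS(=O)(=O)c1ccc(Nc2ncc(F)c(Nc3nc4ccccc4s3)n2)cc1` is the only member of this small set with a numerical result: in a functional assay on PC-3 cells (Homo sapiens) for antiproliferative activity, read by MTT assay, with a stated time of 48 h (on this read-out higher numbers stand for weaker inhibition and lower numbers for stronger inhibition), compound 2 gives 2830 nM. Compound 1 `Cc1cnc(Nc2ccc(Cl)cc2)nc1Nc1nc2ccccc2s1` reaches only a limit of the assay, > 50000 nM. Compound 3 `Cc1cnc(Nc2ccc(S(C)(=O)=O)cc2)nc1Nc1nc2ccc(F)cc2s1` likewise reaches only a limit, > 50000 nM. The picture is thus dominated by the limit of > 50000 nM in this assay, at which 2 of the 3 values shown sit. Compound 4 `CS(=O)(=O)c1ccc(Nc2nccc(Nc3nc4ccccc4s3)n2)cc1` is a not yet measured analogue of compound 2, differing by hydrogen in place of fluoro on an aromatic carbon. Among the compounds with values here, no measured pair in the set isolates this change, so there is nothing to calibrate the step against. Compound 4 is expected, in this assay, to show a step of a 1.8-fold higher number from compound 2 to compound 4 (0.25 log units; within the scatter), a mild weakening that barely exceeds the usual scatter. The estimate for compound 4 is 5000 nM, expected to fall between 1500 nM and 20000 nM.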

Compound 4, half-maximal inhibitory concentration: 1710 nM
Estimate against measurement, compound 4: 2.9-fold (0.47 log units) above, within the range that was stated.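

Hydrogen in place of fluoro on this aromatic carbon of the six-membered aromatic ring with 2 nitrogen gives, in this assay, a 1.7-fold lower number from compound 2 to compound 4 (0.22 log units; within the scatter). Going by these compounds alone, this is the first pair in the set to isolate the change, and it shows that the result stays numerical without the fluoro and that the two compounds cannot be told apart. Nothing measured here offers a reason for this step.

On these data alone, what an amine or a nitrile on this same carbon would give in this assay remains open.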